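Methoxy for hydrogen on the aryl ring: cytotoxicity notes

This account rests on a few compounds, and the source may have more. Where it says the series, first, only, none or still open, it means among the compounds named here.

Measured so far:
compound 1, `COc1ccc(-n2ncn(Cc3cn(Cc4cc5ccccc5nc4Cl)nn3)c2=O)cc1` — 958 ug/mL
compound 2, `O=c1n(Cc2cn(Cc3cc4ccc(Cl)cc4nc3Cl)nn2)cnn1-c1ccccc1` — 869 ug/mL

Both measured compounds were run in an ADME assay on HEK293 cells (Homo sapiens) for cytotoxicity, read by MTT assay; a lower number here means a stronger inhibitor, a higher number a weaker inhibitor. Compound 1 gives 958 ug/mL, and compound 2 gives 869 ug/mL. Compound 2 carries the lower of the two numbers, but the gap to compound 1 lies within the usual scatter of repeated measurements, so the two values are read as equivalent: both compounds are weak inhibitors in this assay.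

Compound 3, `COc1ccc(-n2ncn(Cc3cn(Cc4cc5ccc(Cl)cc5nc4Cl)nn3)c2=O)cc1`, is not yet measured. It differs from compound 2 in one place: methoxy in place of hydrogen on an aromatic carbon. Compound 1 already carries this methoxy group on the same aryl ring, and in this assay compound 1 gives 958 ug/mL, a number indistinguishable from that of compound 2. Going by the values given here, no step between measured compounds is available for this series, so the expectation rests on the two values alone. The step from compound 2 to compound 3 is expected to be a 1.0-fold higher number from compound 2 to compound 3 (0.02 log units; within the scatter), that is, none beyond the scatter. Compound 3 is therefore expected to give about 900 ug/mL in this assay, with a plausible range from 600 ug/mL to 1400 ug/mL.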

Compound 3, half-maximal inhibitory concentration: 1470 ug/mL
For compound 3 the middle estimate is 1.6-fold (0.21 log units) below the measured one; measured number outside the range, above it.
By their numbers in this assay, from the lowest: compounds 2, 1 and 3 (each within the scatter of the next).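

In this assay, methoxy in place of hydrogen on an aromatic carbon, para to a large group, now has a step of its own: a 1.7-fold higher number from compound 2 to compound 3 (0.23 log units; within the scatter) for the change from phenyl to 4-methoxyphenyl, with the chloro present on both compounds. Chloro in place of hydrogen on an aromatic carbon can also now be read alone, with the 4-methoxyphenyl group present on both compounds, and gives a 1.5-fold higher number from compound 1 to compound 3 (0.19 log units; within the scatter) in the same assay, so neither single change moves the number beyond the scatter among the compounds shown. No measurement is at hand that bears on why the numbers fall as they do.

The compounds shown carry only hydrogen or methoxy on the aryl carbon in question, so it remains open whether an amine, a carboxylic acid or a longer alkoxy chain there would give a step beyond the scatter. Going by these compounds, it also remains open whether a group such as bromo or trifluoromethyl at the chloro-bearing carbon would do so, and whether the methoxy step would hold with a different group at that carbon.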